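Unsubstituted Phenyl on the Sulfonyl Sulfur

A few compounds are considered here, and "the series" means these few. Any claim that something is new, unique, unknown or untested is made for them only; others in the source may bear on it.

Compound 1 `CC1CCN(c2c(S(=O)(=O)c3ccc(F)c(F)c3)cnc3c(F)cccc23)CC1` gives 93% in an assay on isolated protein for displacement of a labelled ligand from metabotropic glutamate receptor 5 (Homo sapiens), with a stated time of 60 min, tested at 1 uM; on this read-out higher numbers stand for more inhibition at the one concentration tested (going by the name of the read-out) and lower numbers for less inhibition. Compound 2 `CC1CCN(c2c(S(=O)(=O)c3ccc(F)c(Cl)c3)cnc3cc(F)ccc23)CC1` gives 94% in this assay. Compound 3 `COc1ccc(S(=O)(=O)c2cnc3cc(Cl)ccc3c2N2CCC(C)CC2)cc1OC` gives 93% in this assay.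

Compound 2 has the highest of the three numbers, yet compound 1 and compound 3 each sit only a sliver lower, a gap that stays within the scatter, so the three cannot be ranked. Compound 4 `CC1CCN(c2c(S(=O)(=O)c3ccccc3)cnc3cc(F)ccc23)CC1` differs from compound 2 in one place: phenyl in place of 3-chloro-4-fluorophenyl on a sulfonyl sulfur. Going by the values given here, no measured pair shows the effect of this change, so the expectation rests on the closeness of the three measured numbers. A modest drop in this assay is expected, possibly no larger than the scatter, as a number 7 percentage points lower from compound 2 to compound 4 (within the scatter). For compound 4 the estimate is 87%, between 70% and 97%.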

Compound 4, a percentage reported as inhibition, at one concentration (the size of the read-out at that concentration, not a potency): 87%
Compound 4: middle estimate and measured number agree at the digits printed; low and high end bracket the measured number.
By their numbers in this assay, from the lowest: compounds 4, 1, 3 and 2 (each within the scatter of the next).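

In this assay, going by these compounds alone, the first comparison that changes only this position gives a number 7 percentage points lower from compound 2 to compound 4 (within the scatter), with phenyl in place of 3-chloro-4-fluorophenyl on a sulfonyl sulfur. This pair therefore gives no sign that the chlorine and fluorine on that ring matter at the one concentration tested. Nothing available bears on the reason for this result.

As far as these compounds go, it remains open whether a carboxylic acid or an amine on this phenyl would leave the number within the scatter. Potency also remains open, since a single concentration cannot give it.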